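Swapping 4-Fluorophenyl for Furan-2-yl on the Amide Carbonyl

A few compounds are considered here, and "the series" means these few. Any claim that something is new, unique, unknown or untested is made for them only; others in the source may bear on it.

Of the compounds shown here, two that share one core have been measured in an assay on LtK cells with ATP-sensitive inward rectifier potassium channel 11 (Homo sapiens) as the target; on this read-out lower numbers stand for an effect already at smaller amounts and higher numbers for an effect only at larger amounts of compound. Compound 1 `CCC(C)C(=O)Nc1c(C(O)(C(F)(F)F)C(F)(F)F)ccc2ccccc12` gives 177000 nM. Going by the values given here, compound 2 `O=C(Nc1c(C(O)(C(F)(F)F)C(F)(F)F)ccc2ccccc12)c1ccc(F)cc1` gives 70 nM, the lowest of the two numbers; the step of a 2500-fold lower number from compound 1 to compound 2 (3.40 log units; beyond the scatter) is large and beyond the scatter, so compound 2 stands well ahead of its single neighbour. Compound 3 `O=C(Nc1c(C(O)(C(F)(F)F)C(F)(F)F)ccc2ccccc12)c1ccco1` has not yet been measured. It differs from compound 2 in one place: furan-2-yl in place of 4-fluorophenyl on a carbonyl carbon. Among the compounds with values here, the one measured step bears on this change only loosely, since it exchanged sec-butyl for an aromatic ring, whereas here one aromatic ring gives way to another, a five-membered one with a hetero atom. Compound 3 is therefore expected to keep most of the effect, with an estimated step of a 3.6-fold higher number from compound 2 to compound 3 (0.55 log units; beyond the scatter), modest enough that it might fall within the scatter. In this assay compound 3 is estimated at 250 nM, within a range from 40 nM to 2500 nM.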

Compound 3, half-maximal effective concentration: 9 nM
Compound 3: the middle estimate sits 28-fold (1.44 log units) above what was measured; measured number below the stated range.
By their numbers in this assay, from the lowest: compound 3; then compound 2; then compound 1.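

In this assay the position on the carbonyl carbon proves sensitive to which aromatic ring it carries, and not only to whether it carries one: furan-2-yl, with its five-membered ring and one hetero atom, gives a 7.8-fold lower number from compound 2 to compound 3 (0.89 log units; beyond the scatter). The gain over sec-butyl therefore grows from a 2500-fold lower number from compound 1 to compound 2 (3.40 log units; beyond the scatter) to a 20000-fold lower number from compound 1 to compound 3 (4.29 log units; beyond the scatter), which shows that 4-fluorophenyl did not mark the limit at this place. No measurement offered here accounts for this difference between the two rings.

This single change alters ring size, the ring hetero atom and the fluorine together, so the compounds shown cannot separate these contributions. Plain phenyl, thiophen-2-yl and furan-3-yl would each bear on that question, and how an amine on the furan ring would fare remains open.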